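Carbamoyl for methoxycarbonyl: a swap on the oxazole

This account rests on a few compounds, and the source may have more. Where it says the series, first, only, none or still open, it means among the compounds named here.

Measured compounds:
compound 1 `O=C(CCc1ccc(-c2ccccc2)cc1)c1ncc(-c2ccncc2)o1` 2.3 nM
compound 2 `O=C(O)c1ccc(-c2cnc(C(=O)CCc3ccc(-c4ccccc4)cc3)o2)nc1` 14 nM
compound 3 `COC(=O)c1ccc(-c2cnc(C(=O)CCc3ccc(-c4ccccc4)cc3)o2)cn1` 0.6 nM

In an assay for inhibition of Fatty-acid amide hydrolase 1 (Rattus norvegicus) (a higher number here means a weaker inhibitor, a lower number a stronger inhibitor), compound 3 gives the lowest of the three numbers: the nearest is compound 1, from which the step was a 3.8-fold lower number from compound 1 to compound 3 (0.58 log units; beyond the scatter), and the furthest is compound 2, from which the step was a 23-fold lower number from compound 2 to compound 3 (1.37 log units; beyond the scatter). Compound 4 `NC(=O)c1ccc(-c2cnc(C(=O)CCc3ccc(-c4ccccc4)cc3)o2)nc1` is not yet measured. It differs from compound 3 by 5-carbamoylpyridin-2-yl in place of 6-(methoxycarbonyl)pyridin-3-yl on an aromatic carbon.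

Among the compounds with values here, two measured steps bear on this change. The step of a 23-fold lower number from compound 2 to compound 3 (1.37 log units; beyond the scatter) covers the move from a 5-substituted pyridin-2-yl to a 6-substituted pyridin-3-yl and was large; the step of a 6.1-fold higher number from compound 1 to compound 2 (0.78 log units; beyond the scatter) was modest and in the other direction. Within the data shown here, compound 4 returns to the pyridin-2-yl pattern of compound 2, with a carbamoyl group in place of the carboxylic acid, and no measured pair shows how amide and acid compare here. The number for compound 4 is therefore expected to be higher than that of compound 3, by a step of a 10-fold higher number from compound 3 to compound 4 (1.00 log units; beyond the scatter), while staying near or below the number of compound 2. Compound 4 is estimated at 6 nM, in a range from 1.5 nM to 25 nM.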

Compound 4, inhibition constant: 1.3 nM
Estimate against measurement, compound 4: 4.6-fold (0.66 log units) above, and the stated range ends above it.
By their numbers in this assay, from the lowest: compound 3; then compounds 4 and 1 (each within the scatter of the next); then compound 2.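

Within the 5-substituted pyridin-2-yl series, the one change of amino in place of hydroxy on the carbonyl carbon gives an 11-fold lower number from compound 2 to compound 4 (1.03 log units; beyond the scatter) in this assay. The 5-carbamoylpyridin-2-yl group on the aromatic carbon next to the ring oxygen also stays close to the plain pyridin-4-yl group, with a 1.8-fold lower number from compound 1 to compound 4 (0.25 log units; within the scatter), and it gives up only a modest step against the 6-(methoxycarbonyl)pyridin-3-yl group, with a 2.2-fold higher number from compound 3 to compound 4 (0.34 log units; beyond the scatter). Nothing in the data shown accounts for any of these steps.

That last step changes the carbonyl substituent and the pattern of the pyridine ring together, so the compounds shown do not separate the share of each. Nor do they show whether a methyl-substituted amide or a nitrile in place of the carbamoyl group would hold the number of compound 4 1.3 nM or move it away from that value in this assay.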